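The source may report more compounds than this note shows. Statements on the series, on what has been measured and on what is new or still open speak of the compounds shown alone.

Measured in an ADME assay on L02 cells (Homo sapiens) for antiproliferative activity, read by MTT assay, with a stated time of 48 h; a higher number here means a weaker inhibitor, a lower number a stronger inhibitor:
Compound 1 `N#CC1=C(N)Oc2c(c3nc4ccccc4nc3c3ccccc23)C12C(=O)N(Cc1cnnn1-c1cccc(Cl)c1)c1ccccc12` gives 35200 nM.
Compound 2 `CCOc1ccc(-n2nncc2CN2C(=O)C3(C(C#N)=C(N)Oc4c3c3nc5ccccc5nc3c3ccccc43)c3ccccc32)cc1` gives > 50000 nM, which is a limit of the assay and not a number.
Compound 3 `N#CC1=C(N)Oc2c(c3nc4ccccc4nc3c3ccccc23)C12C(=O)N(Cc1cnnn1-c1ccc(S(N)(=O)=O)cc1)c1ccccc12` gives > 50000 nM, likewise a limit.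

Going by the values given here, compound 1 thus stands as the one compound with a number; the other two values sit at the limit of > 50000 nM in this assay, at which 2 of the 3 values shown sit. Compound 4 `Cc1ccc(-n2nncc2CN2C(=O)C3(C(C#N)=C(N)Oc4c3c3nc5ccccc5nc3c3ccccc43)c3ccccc32)c(C)c1` differs from compound 1 in one place: 2,4-dimethylphenyl in place of 3-chlorophenyl on an aromatic nitrogen. Among the compounds with values here, two measured steps bear on this, each swapping the same 3-chlorophenyl for another group on that aromatic nitrogen: an at least 1.4-fold higher number from compound 1 to compound 2 (0.15 log units; that floor lies within the scatter) and an at least 1.4-fold higher number from compound 1 to compound 3 (0.15 log units; that floor lies within the scatter). Going by these compounds, both are readable only as a floor that lies within the scatter, so their true size is unknown. For compound 4 a step in the same direction, or none beyond the scatter, is therefore expected: a 1.3-fold higher number from compound 1 to compound 4 (0.11 log units; within the scatter). Compound 4 is estimated at 45000 nM, between 25000 nM and 80000 nM.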

Compound 4, half-maximal inhibitory concentration: > 50000 nM
Compound 4: a limit, no number; the forecaster's own chance of this, stated with the estimate: 45%; at least 1.1-fold (0.04 log units) between middle value and limit.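

In this assay, a third replacement of 3-chlorophenyl on this aromatic nitrogen, now 2,4-dimethylphenyl with only carbon on its ring, gives an at least 1.4-fold higher number from compound 1 to compound 4 (0.15 log units; that floor lies within the scatter). Going by these compounds alone, compound 1 therefore remains the only compound here with a number, and the true size of this step is unknown. The steps from compound 2 and compound 3 to compound 4 cannot be read, because all three compounds sit at one limit: the limit of > 50000 nM in this assay, at which 3 of the 4 values shown sit.

The compounds shown leave open how a plain phenyl, a 3-bromophenyl or a phenyl bearing an amine would read at this position. Going by these compounds, whether any group here would give a lower number than compound 1 also stays open.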